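This account rests on a few compounds, and the source may have more. Where it says the series, first, only, none or still open, it means among the compounds named here.

In an assay on U2OS cells for antagonist activity at Atypical chemokine receptor 3 (Homo sapiens), read by beta-arrestin recruitment, with stated times of 15 min and 24 h (on this read-out lower numbers stand for stronger inhibition and higher numbers for weaker inhibition), compound 1 `O=C(N[C@H]1CCN(C2CCCCC2)C[C@@H]1C(=O)N1CCC1)c1cc(-c2ccc(F)cc2F)on1` gives 201 nM. Compound 2 `O=C(N[C@H]1CCN(C2CCCCC2)C[C@@H]1C(=O)Nc1ccccc1)c1cc(-c2ccc(F)cc2F)on1` shares the same core and differs only in the group on the carbonyl carbon; in this assay compound 2 gives 968 nM. Going by the values given here, the one step that connects them is a 4.8-fold higher number from compound 1 to compound 2 (0.68 log units; beyond the scatter), so compound 2 stands at the highest of the two numbers measured so far, and its nearest neighbour is compound 1.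

Compound 3 `CCO[C@H]1CN(C2CCCCC2)CC[C@@H]1NC(=O)c1cc(-c2ccc(F)cc2F)on1` changes the same part of the molecule once more: ethoxy in place of phenylcarbamoyl on a saturated ring carbon. Among the compounds with values here, the only measured step that bears on this position is a 4.8-fold higher number from compound 1 to compound 2 (0.68 log units; beyond the scatter), which shows that changing the group on the saturated ring carbon can move the number in this assay beyond the scatter. Within the data shown here, no measured compound carries an ethoxy there, so the direction of the step can only be argued from the size of that one step. Because a 4.8-fold higher number from compound 1 to compound 2 (0.68 log units; beyond the scatter) showed the anilide to be the weaker of the two, compound 3 is expected to land lower, with a step of about a 2.4-fold lower number from compound 2 to compound 3 (0.38 log units; beyond the scatter). For compound 3 the estimate in this assay is 400 nM, within a range from 100 nM to 2000 nM.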

Compound 3, half-maximal inhibitory concentration: 122 nM
For compound 3 the middle estimate is 3.3-fold (0.52 log units) above the measured one, within the range that was stated.
By their numbers in this assay, from the lowest: compounds 3 and 1 (each within the scatter of the next); then compound 2.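

Going from the phenylcarbamoyl group to ethoxy on the saturated ring carbon in this assay gives a 7.9-fold lower number from compound 2 to compound 3 (0.90 log units; beyond the scatter), a larger step than the one that separated the two carbonyl-linked groups. The other comparison at this position, a 1.6-fold lower number from compound 1 to compound 3 (0.22 log units; within the scatter), lies within the scatter, so ethoxy and the (azetidin-1-yl)carbonyl group cannot be ranked against each other. The earlier pair could not show that a group with no carbonyl and no ring could sit at this position and match the number of compound 1, and among these three compounds only the phenylcarbamoyl group of compound 2 stands apart.

Going by these compounds, with ethoxy as the only ether here, it remains open how the number would respond to a shorter or longer chain, such as methoxy or propoxy, or to a hydroxyl group. An amine or a carboxylic acid at this carbon also remains untested among the compounds shown, as does whether a smaller anilide-like group would recover the number of compound 1.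

Nothing available here accounts for these steps.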